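Swapping Piperidine for Methyl on Compound 3

A few compounds are considered here, and "the series" means these few. Any claim that something is new, unique, unknown or untested is made for them only; others in the source may bear on it.

Compound 3 `c1cnc2ccc(Nc3ncnc4ccc(-c5cnn(C6CCNCC6)c5)cc34)cc2c1` gives the highest number of the three measured compounds in a functional assay on MCF7 cells (Homo sapiens) for antiproliferative activity, read by MTT assay, with a stated time of 72 h (on this read-out lower numbers stand for stronger inhibition and higher numbers for weaker inhibition), at 61900 nM. Compound 1 `CC(Nc1ncnc2ccc(-c3cnn(C4CCNCC4)c3)cc12)c1c(Cl)ccc(F)c1Cl` gives 2650 nM, and compound 2 `CC(Oc1ncnc2ccc(-c3cnn(C4CCNCC4)c3)cc12)c1c(Cl)ccc(F)c1Cl` gives 2670 nM; these two values lie within the usual scatter of each other. The step of a 23-fold higher number from compound 1 to compound 3 (1.37 log units; beyond the scatter) shows how strongly inhibition weakened when the group on the amine nitrogen was exchanged. Compound 4 `Cn1cc(-c2ccc3ncnc(Nc4ccc5ncccc5c4)c3c2)cn1` differs from compound 3 by methyl in place of piperidin-4-yl on an aromatic nitrogen. Among the compounds with values here, no measured step touches this position; the only known step concerns the other end of the shared core, so nothing measured bears directly on this change. The expected step is therefore within the scatter, a 1.3-fold higher number from compound 3 to compound 4 (0.11 log units; within the scatter), for compound 4 in this assay. Compound 4 is estimated at 80000 nM (range 25000 nM to 250000 nM).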

Compound 4, half-maximal inhibitory concentration: 490 nM
Compound 4: the middle estimate sits 160-fold (2.21 log units) above what was measured; the measured number lies below the stated range.
By their numbers in this assay, from the lowest: compound 4; then compounds 1 and 2 (each within the scatter of the next); then compound 3.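

Within the data shown here, the group on the aromatic nitrogen, which no earlier step touched, matters greatly in this assay: methyl in place of piperidin-4-yl gives a 130-fold lower number from compound 3 to compound 4 (2.10 log units; beyond the scatter). The quinolin-6-yl group on the amine nitrogen therefore does not by itself fix a weak result, since it is present on both sides of this step. Still open, on these data alone, is whether an ethyl group or a longer chain on that aromatic nitrogen would hold the gain, and whether methyl would act alike alongside the 1-(2,6-dichloro-3-fluorophenyl)ethyl group. No measurement shown here explains the size of this step.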